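This account rests on a few compounds, and the source may have more. Where it says the series, first, only, none or still open, it means among the compounds named here.

Of the compounds shown here, two of a shared core have been measured in a functional assay on A549 cells (Homo sapiens) for cytotoxicity, read by MTT assay, with a stated time of 72 h; on this read-out lower numbers stand for stronger inhibition and higher numbers for weaker inhibition. Compound 1 `COc1ccc(/C=N/NC(=O)Nc2ccc(Oc3ccnc(-c4nncn4CCN(C)C)c3)c(F)c2)c(OC)c1OC` gives 6680 nM, and compound 2 `CN(C)CCn1cnnc1-c1cc(Oc2ccc(NC(=O)N/N=C/c3ccc(F)cc3)cc2F)ccn1` gives 1790 nM. For the measured compounds named here, the only step so far, a 3.7-fold lower number from compound 1 to compound 2 (0.57 log units; beyond the scatter), shows that the group on the carbon with a double bond to nitrogen can move the read-out beyond the scatter. Compound 2 stands lowest of the two numbers, with compound 1 as its nearest neighbour at a higher value. Compound 3 `CN(C)CCn1cnnc1-c1cc(Oc2ccc(NC(=O)N/N=C/c3cccc(Cl)c3Cl)cc2F)ccn1` differs from compound 2 in one place: 2,3-dichlorophenyl in place of 4-fluorophenyl on a carbon with a double bond to nitrogen. Going by the values given here, no measured step compares these two groups at this position, so the earlier step bears on it only by showing that this position matters, without giving a direction. Compound 3 is therefore expected to differ little, with a 1.2-fold lower number from compound 2 to compound 3 (0.08 log units; within the scatter). The estimate for compound 3 in this assay is 1500 nM, within 500 nM to 5000 nM.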

Compound 3, half-maximal inhibitory concentration: 1090 nM
Estimate against measurement, compound 3: 1.4-fold (0.14 log units) above; measured number inside the range.
By their numbers in this assay, from the lowest: compounds 3 and 2 (each within the scatter of the next); then compound 1.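

In this assay, for the compounds shown here, replacing the 4-fluorophenyl on the carbon with a double bond to nitrogen with 2,3-dichlorophenyl gives a 1.6-fold lower number from compound 2 to compound 3 (0.22 log units; within the scatter) and so does not separate these two groups, which the earlier compounds could not show. The 2,3,4-trimethoxyphenyl group of compound 1 does stand apart from this new group, with a 6.1-fold lower number from compound 1 to compound 3 (0.79 log units; beyond the scatter) for the change at the same position, so among these three compounds the two phenyl groups bearing halogen sit together and compound 1 lies apart from both. No measurement shown here explains this grouping.

As far as these compounds go, it remains open whether a phenyl ring bearing an amine or a carboxylic acid would read like compound 3 or like compound 1. From the compounds shown here alone, whether a phenyl ring with a single methoxy group would join either side also remains open.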